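Bromo for hydroxymethyl on the triazole of compound 2

A few compounds are considered here, and "the series" means these few. Any claim that something is new, unique, unknown or untested is made for them only; others in the source may bear on it.

Compound 2 `O=C1O[C@@H](Cn2cc(CO)nn2)CN1c1ccc(C2=CCS(=O)(=O)CC2)c(F)c1` gives 47000 nM in an assay for binding affinity to Amine oxidase [flavin-containing] A (Homo sapiens) (on this read-out lower numbers stand for stronger inhibition and higher numbers for weaker inhibition), the higher of the two numbers recorded, while compound 3 `Cc1cnnn1C[C@H]1CN(c2ccc(C3=CCS(=O)(=O)CC3)c(F)c2)C(=O)O1` gives 4500 nM in this assay. Compound 1 `C[Si](C)(C)C#Cc1cn(C[C@H]2CN(c3ccc(C4=CCS(=O)(=O)CC4)c(F)c3)C(=O)O2)nn1` reaches only a limit of the assay in this assay, namely > 200000 nM. Of the measured steps, a 10-fold lower number from compound 2 to compound 3 (1.02 log units; beyond the scatter) was large; an at least 4.2-fold lower number from compound 1 to compound 2 (0.62 log units; beyond the scatter) and an at least 44-fold lower number from compound 1 to compound 3 (1.64 log units; beyond the scatter) both start from the limit of > 200000 nM in this assay, at which 1 of the 3 values shown sits, and so give only floors.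

Compound 4 `O=C1O[C@@H](Cn2cc(Br)nn2)CN1c1ccc(C2=CCS(=O)(=O)CC2)c(F)c1` differs from compound 2 by bromo in place of hydroxymethyl on an aromatic carbon. For the measured compounds named here, no measured step exchanges the hydroxymethyl for a halogen at the same place; the nearest comparison, from compound 2 to compound 3, changed the substituent and its place together, so it carries over only loosely. Since every change away from the hydroxymethyl so far gave a lower number, a modest drop with wide uncertainty is expected, as a 2.4-fold lower number from compound 2 to compound 4 (0.37 log units; beyond the scatter). Compound 4 is estimated at 20000 nM, between 5000 nM and 80000 nM.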

Compound 4, inhibition constant: 16000 nM
Beside the measured number, compound 4's estimate is 1.3-fold (0.10 log units) above it, and the stated range covers the measured number.
By their numbers in this assay, from the lowest: compound 3; then compound 4; then compound 2. At a limit, above all of these: compound 1.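

In this assay, a 2.9-fold lower number from compound 2 to compound 4 (0.47 log units; beyond the scatter), so on this aromatic carbon the hydroxymethyl, with its hydrogen-bond donor and acceptor, can give way to a bromo with neither and the number still falls. Even so, there is a 3.6-fold higher number from compound 3 to compound 4 (0.55 log units; beyond the scatter), and since this step changes the substituent and its place together, it cannot say which of the two accounts for it. The remaining step, an at least 12-fold lower number from compound 1 to compound 4 (1.09 log units; beyond the scatter), gives only a floor, as it starts from a limit of the assay: the limit of > 200000 nM in this assay, at which 1 of the 4 values shown sits.

As far as these compounds go, whether a chloro, an amine or a carboxylic acid on this aromatic carbon would lower the number further stays open. Also open, from the compounds shown here alone, is how a methyl on the aromatic carbon that carries the bromo in compound 4 would compare, which would separate substituent from place.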